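This account rests on a few compounds, and the source may have more. Where it says the series, first, only, none or still open, it means among the compounds named here.

Compound 1 `COC(=O)[C@@H]1C[C@@]2(CC=C(C)C)c3ccccc3N3C(=N)[C@H](Cc4ccccc4)N1[C@H]32` — in a functional assay on MDA-MB-231 cells (Homo sapiens) for cytotoxicity, read by sulforhodamine B assay, with a stated time of 48 h (a higher number here means a weaker inhibitor of growth, a lower number a stronger inhibitor of growth), compound 1 gives > 100000 nM, which is a limit of the assay and not a number.
Compound 2 `COC(=O)[C@@H]1C[C@@]2(CC=C(C)C)c3ccccc3N3C(=N)[C@H](c4ccccc4)N1[C@H]32` — in this assay compound 2 gives > 100000 nM, again only a limit.

Compound 1 therefore stands at the limit of > 100000 nM in this assay, at which 2 of the 2 values shown sit, with no number of its own. Among the compounds with values here, the only measured step, a step that the two limits leave unreadable from compound 1 to compound 2, runs between two limits, so its size cannot be read. Compound 3 `COC(=O)[C@@H]1C[C@]2(CC=C(C)C)c3ccccc3N3C(=N)[C@@H](Cc4ccccc4)N1[C@@H]32` keeps every atom and bond of compound 1 and differs only in spatial arrangement: the two compounds have the same atoms and bonds; at least one stereo element is drawn with a configuration in one of them and without one in the other: 3 of 5 stereo elements differ; a stereocentre at a saturated ring carbon is drawn S in compound 1 and R in compound 3; a stereocentre at a saturated ring carbon is drawn S in compound 1 and R in compound 3; a stereocentre at a saturated ring carbon is drawn R in compound 1 and S in compound 3. No measured step changes a stereocentre, so nothing shown tells how large such a change is, in either direction. With compound 1 resting at a limit, the expectation for compound 3 can only be placed at that same limit, with a wide range. Compound 3 is estimated at 100000 nM, between 30000 nM and 300000 nM. The step this estimate means, a number no higher from compound 1 to compound 3 (the limit leaves the size open), is expected to be none beyond the scatter.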

Compound 3, concentration for 50% growth inhibition: 9390 nM
Estimate against measurement, compound 3: 11-fold (1.03 log units) above; measured number outside the range, below it.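

In this assay, a change in spatial arrangement alone, with the same atoms and bonds and three stereocentres at saturated ring carbons altered, gives an at least 10-fold lower number from compound 1 to compound 3 (1.02 log units; beyond the scatter). This is the only step shown whose size can be read, and because one end of it is a limit, it gives a minimum and not an exact size. It shows that the arrangement at these stereocentres can separate a measured number from a limit on the same core, which the step from benzyl to phenyl could not show, since its size cannot be read: the limit of > 100000 nM in this assay, at which 2 of the 3 values shown sit.

Which of the three stereocentres accounts for the step stays open, and the comparison carries a caution: the fact that one of compounds 1 and 3 is drawn with a defined configuration and the other without, at the place where they differ Also open is whether replacing the benzyl group of compound 3 with phenyl, an amine or a carboxylic acid would move its number.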